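Compound 3 after the methylbenzoxazole: clearance notes

A few compounds are considered here, and "the series" means these few. Any claim that something is new, unique, unknown or untested is made for them only; others in the source may bear on it.

Measured so far in an ADME assay (liver) for metabolic stability, with Liver microsome (Rattus norvegicus) as the target, using microsomes and NADPH, with a stated time of 30 min, tested at 1 uM (on this read-out lower numbers stand for slow clearance and higher numbers for fast clearance), for the series:
compound 1 `Nc1ccc(S(=O)(=O)N2CCN(c3ncc(C(O)(C(F)(F)F)C(F)(F)F)cc3-c3ccc4sccc4c3)CC2)cn1` gives 487 mL.min-1.g-1 here
compound 2 `Cc1nc2cc(-c3cc(C(O)(C(F)(F)F)C(F)(F)F)cnc3N3CCN(S(=O)(=O)c4ccc(N)nc4)CC3)ccc2o1` gives 99 mL.min-1.g-1 here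

Compound 2 holds the lower of the two numbers. The next change is 1H-indazol-5-yl in place of 2-methyl-1,3-benzoxazol-5-yl on an aromatic carbon and gives compound 3 `Nc1ccc(S(=O)(=O)N2CCN(c3ncc(C(O)(C(F)(F)F)C(F)(F)F)cc3-c3ccc4[nH]ncc4c3)CC2)cn1` on the same core. For the measured compounds named here, one measured step bears on it, at the same place: a 4.9-fold lower number from compound 1 to compound 2 (0.69 log units; beyond the scatter), which is modest and beyond the scatter. Going by these compounds, that step does not involve 1H-indazol-5-yl, so no step beyond the scatter is expected in this assay and the direction stays open. The estimated step is a 1.2-fold higher number from compound 2 to compound 3 (0.08 log units; within the scatter) and should be read as such. For compound 3 the expected value is 120 mL.min-1.g-1, with an estimated range of 45 mL.min-1.g-1 to 320 mL.min-1.g-1 here.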

Compound 3, intrinsic clearance in microsomes: 88 mL.min-1.g-1
Compound 3: middle estimate off by 1.4-fold (0.13 log units), on the high side; the measured number falls inside the stated range.
By their numbers in this assay, from the lowest: compounds 3 and 2 (each within the scatter of the next); then compound 1.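

In this assay, 1H-indazol-5-yl and 2-methyl-1,3-benzoxazol-5-yl cannot be told apart at this position (a 1.1-fold lower number from compound 2 to compound 3 (0.05 log units; within the scatter)), although the first carries a hydrogen-bond donor and the second none. Compound 3 also stands clear of the 1-benzothiophen-5-yl compound (a 5.5-fold lower number from compound 1 to compound 3 (0.74 log units; beyond the scatter)), so a second group on this aromatic carbon now gives a number beyond the scatter from compound 1. Nothing measured on these compounds accounts for this.

Going by these compounds, whether a 1-methyl-1H-indazol-5-yl group would give a similar number remains open. So does the outcome for a plain phenyl ring or a simple amine on this carbon.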